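Chloro to Amino on the Shared Core

The source may hold more compounds than are shown below. What is called first, only, known or untested is meant among the compounds shown, and "the series" means these compounds.

In a functional assay on HOP-92 cells (Homo sapiens) for antiproliferative activity, read by sulforhodamine B assay, with a stated time of 48 h (a lower number here means a stronger inhibitor of growth, a higher number a weaker inhibitor of growth), compound 2 `Nc1nn(C(=O)Nc2ccc(Cc3ccccc3)cc2)c2ccc(Cl)cc12` gives 10700 nM, while compound 1 `Nc1nn(C(=O)Nc2ccc(Cc3ccccc3)cc2)c2ccccc12` gives 14200 nM, and the step of a 1.3-fold lower number from compound 1 to compound 2 (0.12 log units; within the scatter) lies within the scatter. Compound 3 `Nc1ccc2c(c1)c(N)nn2C(=O)Nc1ccc(Cc2ccccc2)cc1` carries amino in place of chloro on an aromatic carbon. Among the measured compounds shown here, the only measured step alters the same place on the core, chloro in place of hydrogen, and it stayed within the scatter; no measured step involves an amino group. For compound 3 the expected step is a 1.1-fold higher number from compound 2 to compound 3 (0.05 log units; within the scatter), nothing beyond the scatter. Compound 3 is therefore estimated at 12000 nM, with a likely range from 5000 nM to 30000 nM.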

Compound 3, concentration for 50% growth inhibition: 10400 nM
Compound 3: middle estimate off by 1.2-fold (0.06 log units), on the high side, and the stated range covers the measured number.
By their numbers in this assay, from the lowest: compounds 3, 2 and 1 (each within the scatter of the next).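

With amino in place of chloro, this assay shows a 1.0-fold lower number from compound 2 to compound 3 (0.01 log units; within the scatter) and with amino in place of hydrogen, it shows a 1.4-fold lower number from compound 1 to compound 3 (0.14 log units; within the scatter) so both steps stay within the scatter. This position has now carried hydrogen, chloro and amino, including a group with a hydrogen-bond donor and acceptor that chloro lacks, without a change beyond the scatter. No measured evidence is available to explain this result.

As far as these compounds go, whether a carboxylic acid or a longer chain such as butoxy at this position would shift the number beyond the scatter remains open.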